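A few compounds are considered here, and "the series" means these few. Any claim that something is new, unique, unknown or untested is made for them only; others in the source may bear on it.

Of the compounds shown here, three that share one core have so far been measured in an assay on HL-60 cells for agonist activity at vitamin D3 receptor (Homo sapiens), read by microscopy, with a stated time of 96 h; on this read-out higher numbers stand for an effect only at larger amounts of compound and lower numbers for an effect already at smaller amounts. Compound 1 `CCn1c(C(=O)NCC(OC)OC)ccc1C(CC)(CC)c1ccc(OCC(=O)C(C)(C)C)c(C)c1` gives 130 nM. Compound 2 `CCn1c(C(=O)N(C)CCC#N)ccc1C(CC)(CC)c1ccc(OCC(=O)C(C)(C)C)c(C)c1` gives 9800 nM, and compound 3 `C=CCN(C)C(=O)c1ccc(C(CC)(CC)c2ccc(OCC(=O)C(C)(C)C)c(C)c2)n1CC` gives 21600 nM. Compound 3 therefore carries the highest number of the three, since a 2.2-fold higher number from compound 2 to compound 3 (0.34 log units; beyond the scatter) and a 170-fold higher number from compound 1 to compound 3 (2.22 log units; beyond the scatter). The next compound, compound 4 `CC[C@@H](C)[C@H](NC(=O)c1ccc(C(CC)(CC)c2ccc(OCC(=O)C(C)(C)C)c(C)c2)n1CC)C(=O)O`, differs from compound 3 in one place: (1-carboxy-2-methylbutyl)amino in place of allyl(methyl)amino on a carbonyl carbon. For the measured compounds named here, no measured step puts a carboxy-bearing group onto the amide, so the bearing steps are indirect. The two steps that replace the (2,2-dimethoxyethyl)amino group with a methyl-bearing amino group were both large, namely a 75-fold higher number from compound 1 to compound 2 (1.88 log units; beyond the scatter) and a 170-fold higher number from compound 1 to compound 3 (2.22 log units; beyond the scatter), whereas the step between the two methyl-bearing amides, a 2.2-fold higher number from compound 2 to compound 3 (0.34 log units; beyond the scatter), was modest. Compound 4, like compound 1 with its 130 nM, carries an amino group without a methyl on the nitrogen, which points toward a lower number, though the carboxy group is new to the set. Compound 4 is accordingly expected to show a 27-fold lower number from compound 3 to compound 4 (1.43 log units; beyond the scatter), with an estimated 800 nM in a range from 80 nM to 8000 nM.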

Compound 4, half-maximal effective concentration: 10 nM
The estimate for compound 4 lay 80-fold (1.90 log units) above the measured number; the whole stated range lies above it.
By their numbers in this assay, from the lowest: compound 4; then compound 1; then compound 2; then compound 3.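

On this carbonyl carbon, in this assay, the (1-carboxy-2-methylbutyl)amino group gives the lowest number of the set, with a 2200-fold lower number from compound 3 to compound 4 (3.33 log units; beyond the scatter) and a 980-fold lower number from compound 2 to compound 4 (2.99 log units; beyond the scatter), and it also goes clearly past the (2,2-dimethoxyethyl)amino group, with a 13-fold lower number from compound 1 to compound 4 (1.11 log units; beyond the scatter). The earlier compounds shown here left the (2,2-dimethoxyethyl)amino group as the best at this place, whereas compound 4 shows that a chain bearing a carboxy group can be carried here and can reach lower still. No measurement is available that would explain the size of these steps.

The change brings in the carboxy group, the branched chain and the 2 defined stereocentres together, and the compounds shown do not separate them. Going by these compounds, it remains open how a methyl ester in place of the carboxylic acid, a shorter unbranched chain with the same acid, or the opposite stereoisomer would read.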